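Aryl swap on the acid series: cytotoxicity outlook

The source may hold more compounds than are shown below. What is called first, only, known or untested is meant among the compounds shown, and "the series" means these compounds.

compound 1 `COc1ccc(/C=C2\CC[C@H]3C(C)(C)CCC[C@]3(C)[C@H]2CCC(C)CC(=O)O)cc1` — > 200000 nM
compound 2 `COc1ccc(/C=C2\CC[C@H]3C(C)(C)CCC[C@]3(C)[C@H]2CCC(C)CC(=O)O)cc1OC` — > 200000 nM
compound 3 `CC(CC[C@H]1/C(=C/c2ccc(F)cc2)CC[C@H]2C(C)(C)CCC[C@]12C)CC(=O)O` — not yet measured

In an ADME assay on HUVEC cells (Homo sapiens) for cytotoxicity, read by MTT assay, with a stated time of 24 h (on this read-out higher numbers stand for weaker inhibition and lower numbers for stronger inhibition), compound 1 gives > 200000 nM, a limit of the assay. Compound 2 gives > 200000 nM, also a limit. The step that the two limits leave unreadable from compound 1 to compound 2 therefore cannot be read. Compound 2 stands at the limit of > 200000 nM in this assay, at which 2 of the 2 values shown sit. Compound 3 carries 4-fluorophenyl in place of 3,4-dimethoxyphenyl on a double-bonded chain carbon bound to a double-bonded ring carbon. No readable measured step bears on this change, so no direction beyond the scatter is expected; the expected step is a number no higher from compound 2 to compound 3 (the limit leaves the size open), most likely ending again at the limit. Compound 3 is estimated at 200000 nM, within 100000 nM to 400000 nM.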

Compound 3, half-maximal inhibitory concentration: > 200000 nM
Compound 3: no number, only a limit; the forecaster's own chance of this, stated with the estimate: 85%; the middle value lies on the limit itself.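

In this assay, within the data shown here, compound 3 gives > 200000 nM, a limit of the assay, and no step among compound 1, compound 2 and compound 3 can be read: the limit of > 200000 nM in this assay, at which 3 of the 3 values shown sit.

Still open, going by these compounds, is whether any aryl group on the shared core gives a readable value in this assay.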